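A few compounds are considered here, and "the series" means these few. Any claim that something is new, unique, unknown or untested is made for them only; others in the source may bear on it.

In an assay for binding affinity to Alpha-1A adrenergic receptor (Homo sapiens) (on this read-out lower numbers stand for stronger inhibition and higher numbers for weaker inhibition), compound 3 `CN1CCC[C@@H]1Cn1nc(Cc2cccc(F)c2)c2ccccc2c1=O` gives 50.1 nM, the lowest of the two numbers shown. Compound 2 `CN1CCC[C@@H]1Cn1nc(CCc2ccccc2)c2ccccc2c1=O` gives 200 nM, and the step of a 4.0-fold lower number from compound 2 to compound 3 (0.60 log units; beyond the scatter). For compound 1 `CN1CCC[C@@H]1Cn1nc(Cc2ccc(C(C)(C)C)cc2)c2ccccc2c1=O` the assay reports only a limit, > 1990 nM (the limit of > 1990 nM in this assay, at which 1 of the 3 values shown sits). Compound 4 `COc1ccc(Cc2nn(C[C@H]3CCCN3C)c(=O)c3ccccc23)cc1` differs from compound 3 in one place: 4-methoxyphenyl in place of 3-fluorophenyl on a saturated chain carbon bound to an aromatic carbon. Going by the values given here, no measured step swaps one ring substituent for another, so the single modest step from compound 2 to compound 3 is the only direct guide, while compound 1 shows that another substituent on this ring can push the number to the limit. The expected step is a 3.0-fold higher number from compound 3 to compound 4 (0.48 log units; beyond the scatter), towards a weaker number. Compound 4 is estimated at 150 nM, within 50 nM to 500 nM.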

Compound 4, inhibition constant: 126 nM
The estimate for compound 4 lay 1.2-fold (0.08 log units) above the measured number, and the stated range covers the measured number.
By their numbers in this assay, from the lowest: compound 3; then compounds 4 and 2 (each within the scatter of the next). At a limit, above all of these: compound 1.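

In this assay, replacing 3-fluorophenyl with 4-methoxyphenyl on this chain carbon has a measurable cost: a 2.5-fold higher number from compound 3 to compound 4 (0.40 log units; beyond the scatter). The comparison with compound 2 shows no clear change: a 1.6-fold lower number from compound 2 to compound 4 (0.20 log units; within the scatter). On the aromatic carbon, methoxy in place of tert-butyl gives an at least 15-fold lower number from compound 1 to compound 4 (1.19 log units; beyond the scatter), but compound 1 is known only as a limit: the limit of > 1990 nM in this assay, at which 1 of the 4 values shown sits.

As far as these compounds go, the group and its place on the ring both change between compound 3 and compound 4, so their separate contributions remain unresolved. 3-Methoxyphenyl and 4-fluorophenyl would separate them, while an amine on the ring remains open.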